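The compounds below may be only part of what the source reports. "The series", "measured", "known", "first", "only" and "open" are said of these compounds alone.

In a functional assay on SGC-7901 cells (Homo sapiens) for antiproliferative activity, read by MTT assay, with a stated time of 72 h (a lower number here means a stronger inhibitor, a higher number a weaker inhibitor), three compounds have been measured so far:

Compound 1 `COc1ccc(-c2ssc(=O)c2-c2cc(OC)c(OC)c(OC)c2)cc1`: 134 nM
Compound 2 `COc1ccc(-c2ssc(=O)c2-c2cc(OC)c(OC)c(OC)c2)cc1[N+](=O)[O-]`: 440 nM
Compound 3 `COc1ccc(-c2c(-c3cc(OC)c(OC)c(OC)c3)ss/c2=N/O)cc1`: > 100000 nM

For compound 3 the entry of > 100000 nM is a limit of the assay, not a number. It is the limit of > 100000 nM in this assay, at which 1 of the 3 values shown sits.

Compound 1 and compound 2 share one core, and compound 3 carries a different one; the difference between the two cores is not broken down here. Compound 1 and compound 2 differ only by nitro in place of hydrogen on an aromatic carbon. That change gave a 3.3-fold higher number from compound 1 to compound 2 (0.52 log units; beyond the scatter).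

Compound 4 `COc1ccc(-c2c(-c3cc(OC)c(OC)c(OC)c3)ss/c2=N/O)cc1[N+](=O)[O-]` has not yet been measured. It stands to compound 3 exactly as compound 2 stands to compound 1, by nitro in place of hydrogen on an aromatic carbon, the same change at the same place.

Compound 3 already sits at a limit. Because the earlier step of a 3.3-fold higher number from compound 1 to compound 2 (0.52 log units; beyond the scatter) made the number higher rather than lower, there is little reason to expect compound 4 to come within reach of the assay. The step expected here is a step that the limit leaves unreadable from compound 3 to compound 4, an estimate that rests on a 3.3-fold higher number from compound 1 to compound 2 (0.52 log units; beyond the scatter). Compound 4 is therefore estimated at 200000 nM, and most likely the assay would again report only a limit.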

Compound 4, half-maximal inhibitory concentration: 6560 nM
The estimate for compound 4 lay 30-fold (1.48 log units) above the measured number, and the stated range ends above it.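

In this assay, nitro in place of hydrogen on the aromatic carbon gave an at least 15-fold lower number from compound 3 to compound 4 (1.18 log units; beyond the scatter), so on these two cores the same change did not even move the number in the same direction: the same change on two cores in this assay, a 3.3-fold higher number (0.52 log units; beyond the scatter) from compound 1 to compound 2 and an at least 15-fold lower number (1.18 log units; beyond the scatter) from compound 3 to compound 4, at least 50-fold (1.69 log units) apart, beyond the scatter of two such steps

Compound 3 stands at a limit of the assay, not at a number: the limit of > 100000 nM in this assay, at which 1 of the 4 values shown sits.

The size of the new step is therefore known only as a bound, and with a single pair on each core these results show that the effect of this change cannot be carried from one core to the other here, but they do not show why the two cores differ or how a third core would respond.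

From the compounds shown here alone, it remains open whether an amine or a carboxylic acid in place of the nitro, at the same place on the ring, would also split between the two cores. Going by these compounds, it also remains open whether the gain seen on the core of compound 3 belongs to nitro alone or would appear with other groups there.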